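From propoxy to chloro: expected clearance of compound 3

The source may report more compounds than this note shows. Statements on the series, on what has been measured and on what is new or still open speak of the compounds shown alone.

Compound 1 `CCOC(=O)c1c(-c2cccc(-c3ccccc3)c2)[nH]c2cc(OC)ccc2c1=O`: 5.7 mL.min-1.g-1
Compound 2 `CCCOc1cccc(-c2[nH]c3cc(OC)ccc3c(=O)c2C(=O)OCC)c1`: 39 mL.min-1.g-1

In an in vitro ADME assay on microsomes from liver (Mus musculus, strain CD1) for metabolic stability, read by HPLC, with a stated time of 4 h (on this read-out lower numbers stand for slow clearance and higher numbers for fast clearance), compound 2, at 39 mL.min-1.g-1, stands highest of the two measured compounds, and its nearest neighbour is compound 1, at 5.7 mL.min-1.g-1. The next structure, compound 3 `CCOC(=O)c1c(-c2cccc(Cl)c2)[nH]c2cc(OC)ccc2c1=O`, has chloro in place of propoxy on an aromatic carbon. Among the measured compounds shown here, only one measured step bears on this change: a 6.8-fold higher number from compound 1 to compound 2 (0.84 log units; beyond the scatter). That step, with propoxy in place of phenyl on an aromatic carbon, lies beyond the scatter, so a change of group at this carbon can shift the number appreciably. For the measured compounds named here, no measurement yet includes chloro, and a single step cannot establish a trend, so the expectation is only tentative. Compound 3 is expected to fall between the two measured values in this assay, which makes a lower number than that of compound 2 the likelier direction. The estimated step is a 2.8-fold lower number from compound 2 to compound 3 (0.44 log units; beyond the scatter). For compound 3 the expected value is 14 mL.min-1.g-1, with an estimated range of 5 mL.min-1.g-1 to 40 mL.min-1.g-1.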

Compound 3, intrinsic clearance in microsomes: 16 mL.min-1.g-1
Compound 3: middle estimate off by 1.1-fold (0.06 log units), on the low side, within the range that was stated.
By their numbers in this assay, from the lowest: compound 1; then compound 3; then compound 2.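

In this assay chloro in place of propoxy on this aromatic carbon gives a 2.4-fold lower number from compound 2 to compound 3 (0.39 log units; beyond the scatter) and chloro in place of phenyl gives a 2.8-fold higher number from compound 1 to compound 3 (0.45 log units; beyond the scatter) on the same read-out, so three groups at one position now form an order, with phenyl lowest, chloro in the middle and propoxy highest, each gap beyond the scatter. Chloro, with its single heavy atom, does not give the lowest number but falls inside the span set by the two larger groups, so among these three compounds the size of the group alone does not set the order. Nothing available explains this order or ties it to any measured property of the groups.

On these data alone, whether the order extends to other groups on this carbon remains open, since an amine, a carboxylic acid, a fluoro group or a chain longer than propoxy could fall anywhere relative to these three. As far as these compounds go, all three compounds also share the same core, so it is unknown whether the order would survive a change elsewhere in the molecule.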